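Swapping amino for nitro in compound 1

This account rests on a few compounds, and the source may have more. Where it says the series, first, only, none or still open, it means among the compounds named here.

- Compound 1 (`COc1ccc(Cc2ccc(OC)c(OC)c2OC)cc1N`) gives 330 nM
- Compound 2 (`CCn1ccc2cc(Cc3ccc(OC)c(OC)c3OC)ccc21`) gives > 1000 nM (a limit)
- Compound 3 (`COc1cc(Cc2ccc3ccccc3c2)cc(OC)c1OC`) gives 250 nM

Within the data shown here, in a functional assay on HT-29 cells (Homo sapiens) for cytotoxicity, read by XTT assay, with a stated time of 72 h (a lower number here means a stronger inhibitor, a higher number a weaker inhibitor), compound 1 sits at 330 nM and compound 3 at 250 nM as the only two true numbers, and these lie within the usual scatter of each other. For compound 2 the entry > 1000 nM is a limit of the assay and not a number.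

Compound 4 (`COc1ccc(Cc2ccc(OC)c(OC)c2OC)cc1[N+](=O)[O-]`) differs from compound 1 in one place: nitro in place of amino on an aromatic carbon, ortho to a methoxy group. Among the measured compounds shown here, no measured pair shows this swap, so the data give no direct size for the step. Starting from compound 1 at 330 nM a moderate step towards a weaker inhibitor is expected. A result that is only a limit is also possible (the limit of > 1000 nM in this assay, at which 1 of the 3 values shown sits). The estimated change is a modest one (a 2.7-fold higher number from compound 1 to compound 4 (0.44 log units; beyond the scatter)). For compound 4 the estimated value is 900 nM (range 250 nM to 3000 nM).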

Compound 4, half-maximal inhibitory concentration: 2900 nM
The estimate for compound 4 lay 3.2-fold (0.51 log units) below the measured number; low and high end bracket the measured number.
By their numbers in this assay, from the lowest: compounds 3 and 1 (each within the scatter of the next); then compound 4.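

In this assay, swapping in nitro for amino gives an 8.8-fold higher number from compound 1 to compound 4 (0.94 log units; beyond the scatter). Among these compounds, this is the first direct measure of a change at this position, on an aromatic carbon ortho to a methoxy group, and it shows that this single swap moves the number beyond the scatter while the rest of the core of compound 1 stays the same. Compound 2 remains a limit and not a number, so it cannot be ranked against compound 4: the limit of > 1000 nM in this assay, at which 1 of the 4 values shown sits.

A single pair cannot tell whether amino favours a lower number or nitro favours a higher one. A hydroxyl group, an acetamide or a dimethylamino group at this position would help separate these two readings, and the compounds shown leave that open.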